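Swapping an amine on a shared core against an enzyme

A few compounds are considered here, and "the series" means these few. Any claim that something is new, unique, unknown or untested is made for them only; others in the source may bear on it.

Of the compounds shown here, three built on one shared core have been tested in an assay on HEK293 cells for inhibition of Fatty-acid amide hydrolase 1 (Homo sapiens), read by fluorescence; a higher number here means a weaker inhibitor, a lower number a stronger inhibitor. Compound 1 `NC(=O)Cn1ccc2cc(-c3ccc4oc(NC5CCCCC5)nc4c3)ccc21` gives 214 nM in this assay, compound 2 `COc1ccc(Nc2nc3cc(-c4ccc5c(ccn5C)c4)ccc3o2)cc1` gives 280 nM, and compound 3 `Cn1ccc2cc(-c3ccc4oc(N5CCc6ccccc6C5)nc4c3)ccc21` gives 55 nM. Of these three numbers compound 2 holds the highest; compound 1 sits within the scatter of it, so no order between those two can be read, while compound 3 sits beyond the scatter with the lower number.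

Compound 4 `Cn1ccc2cc(-c3ccc4oc(N5CCn6cccc6C5)nc4c3)ccc21` has not yet been measured. It differs from compound 2 in one place: a group of 9 heavy atoms (7 carbon, 2 nitrogen; one five-membered aromatic ring with 1 hetero atom, one six-membered non-aromatic ring with 2 hetero atoms) in place of a group of 9 heavy atoms (7 carbon, 1 nitrogen, 1 oxygen; one six-membered aromatic ring of carbon only), on an aromatic carbon. Compound 3 likewise carries a ring-fused amine rather than an aryl amine at that aromatic carbon, and compound 3 stands well below compound 2. Among the compounds with values here, no single-change step between measured compounds is available, so the expectation rests on that comparison alone.

Compound 4 is expected to fall below compound 2, with an estimated step of a 3.5-fold lower number from compound 2 to compound 4 (0.54 log units; beyond the scatter) in this assay, beyond the scatter and in the direction of compound 3. The estimate for compound 4 in this assay is 80 nM, with a likely range from 25 nM to 250 nM.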

Compound 4, half-maximal inhibitory concentration: 42 nM
The estimate for compound 4 lay 1.9-fold (0.28 log units) above the measured number, and the stated range covers the measured number.
By their numbers in this assay, from the lowest: compounds 4 and 3 (each within the scatter of the next); then compounds 1 and 2 (each within the scatter of the next).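

This position on the shared core now has its first single-change step in this assay: a 6.7-fold lower number from compound 2 to compound 4 (0.82 log units; beyond the scatter), beyond the scatter, when the (4-methoxyphenyl)amino group gives way to the fused ring amine on an aromatic carbon of the five-membered aromatic ring with 1 nitrogen and 1 oxygen. Both groups hold 9 heavy atoms and 2 hydrogen-bond acceptors, so these counts stay the same, while the hydrogen-bond donors go from 1 to 0 and the ring make-up changes; the step alone cannot separate these differences. Compound 3 at 55 nM and compound 4 at 42 nM lie within the scatter of each other, so two different fused ring amines give values that cannot be ordered here, and no measurement is available to explain the gain over the aryl amine.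

A simpler ring amine without a fused ring, such as piperidine or morpholine, would show whether the fused ring is needed at all. A (4-methoxyphenyl)(methyl)amino group, which keeps the aryl ring but has no amine hydrogen, would test the role of that hydrogen on its own.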